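From 3-Chlorophenyl to 2-Fluorophenyl on the Sulfonyl Sulfur

The compounds below may be only part of what the source reports. "The series", "measured", "known", "first", "only" and "open" are said of these compounds alone.

Of the compounds shown here, two sharing one core have been measured in an assay on MDA-MB-231 cells for displacement of a labelled ligand from C-X-C chemokine receptor type 4 (Homo sapiens), read by fluorescence and microscopy, with stated times of 10 min and 30 min; a higher number here means that more compound is needed for the effect, a lower number that less compound is needed. Compound 1 `Cc1ccccc1C(=O)NCc1ccc(CNS(=O)(=O)c2ccccc2C)cc1` gives 10 nM. For the measured compounds named here, compound 2 `Cc1ccccc1C(=O)NCc1ccc(CNS(=O)(=O)c2cccc(Cl)c2)cc1` gives 100 nM, the highest of the two numbers, and the only known step, a 10-fold higher number from compound 1 to compound 2 (1.00 log units; beyond the scatter), is what sets it apart. Compound 3 `Cc1ccccc1C(=O)NCc1ccc(CNS(=O)(=O)c2ccccc2F)cc1` has not yet been measured; it differs from compound 2 in one place (2-fluorophenyl in place of 3-chlorophenyl on a sulfonyl sulfur). Going by the values given here, the one measured step bears on this change, since it also exchanged the ring on the sulfonyl sulfur and moved the number beyond the scatter. Returning to a ring bearing a 2-substituent is therefore expected to bring the number down again, though fluorine is not methyl, so only part of that step is expected to be recovered. Compound 3 is estimated at 30 nM, with a range from 10 nM to 100 nM. This is expected to amount to a 3.3-fold lower number from compound 2 to compound 3 (0.52 log units; beyond the scatter).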

Compound 3, effective concentration (reported as EC, without a stated level of effect): 1000 nM
Estimate against measurement, compound 3: 33-fold (1.52 log units) below, outside the stated range (above it).
By their numbers in this assay, from the lowest: compound 1; then compound 2; then compound 3.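

In this assay, exchanging 3-chlorophenyl for 2-fluorophenyl on the sulfonyl sulfur gives a 10-fold higher number from compound 2 to compound 3 (1.00 log units; beyond the scatter) and so shows that a 2-substituted ring does not by itself keep the number low. For the compounds shown here, the sharper comparison is fluoro in place of methyl on an aromatic carbon, which gives a 100-fold higher number from compound 1 to compound 3 (2.00 log units; beyond the scatter) and is the largest step so far, so at this position the identity of that one group matters greatly. Nothing measured here accounts for this difference.

As far as these compounds go, it remains open where a 2-chlorophenyl or 2-ethylphenyl group on the sulfonyl sulfur would fall relative to compound 1 and compound 3, and what an amine or a carboxylic acid on that ring would do. The compounds shown also leave open how the number responds to changes elsewhere in the shared core.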